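The source may report more compounds than this note shows. Statements on the series, on what has been measured and on what is new or still open speak of the compounds shown alone.

Three compounds here share one core and differ only in the group attached to a carbonyl carbon. In an assay on membranes from HeLa cells for displacement of a labelled ligand from adenosine receptor A3 (Homo sapiens), read by scintillation counting, with a stated time of 180 min, tested at 1 uM (on this read-out higher numbers stand for more inhibition at the one concentration tested (going by the name of the read-out) and lower numbers for less inhibition), compound 3 `CCNC(=O)C1=C(C)NC(=O)NC1c1cccs1` gives 4%, the second highest of the three numbers. Compound 1 `CC1=C(C(=O)OC(C)(C)C)C(c2cccs2)NC(=O)N1` gives 7% in this assay, and compound 2 `CCCC(=O)C1=C(C)NC(=O)NC1c1cccs1` gives 2%. Both steps toward compound 3 stay within the scatter: a number 3 percentage points lower from compound 1 to compound 3 (within the scatter) and a number 2 percentage points higher from compound 2 to compound 3 (within the scatter), as does a number 5 percentage points lower from compound 1 to compound 2 (within the scatter). Compound 4 `CCSC(=O)C1=C(C)NC(=O)NC1c1cccs1` is not yet measured; its change is ethylsulfanyl in place of ethylamino on a carbonyl carbon. Every measured swap at this same carbonyl carbon moved the inhibition by an amount within the scatter, so no step beyond the scatter is expected in this assay for compound 4. The estimated step is no change at the digits printed from compound 3 to compound 4 (within the scatter). Compound 4 is expected to give about 4%, between -6% and 14%.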

Compound 4, a percentage reported as inhibition, at one concentration (the size of the read-out at that concentration, not a potency): 1%
Compound 4: the middle estimate sits 3 percentage points above what was measured; the range from low to high includes it.
By their numbers in this assay, from the lowest: compounds 4, 2, 3 and 1 (each within the scatter of the next).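

Ethylsulfanyl in place of ethylamino removes the hydrogen-bond donor from this group and brings in sulfur, yet this assay shows a number 3 percentage points lower from compound 3 to compound 4 (within the scatter). The comparisons with the other two groups on this carbonyl carbon give a number 1 percentage points lower from compound 2 to compound 4 (within the scatter) and a number 6 percentage points lower from compound 1 to compound 4 (within the scatter), so this swap, like the earlier ones, produces no step beyond the scatter. No supporting data explain these numbers. From the compounds shown here alone, whether a carboxylic acid, an unsubstituted amine or a longer chain on this carbonyl carbon would move the inhibition beyond the scatter remains open.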